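Carbamate in place of pyrrolidinylmethyl on the amine nitrogen

The source may report more compounds than this note shows. Statements on the series, on what has been measured and on what is new or still open speak of the compounds shown alone.

Among the measured compounds shown here, compound 2 `CCC(C)[C@H](NC[C@@H]1CCCN1)c1cc(C(F)(F)F)ccc1N1CCN(C(=O)CCc2ccc(Cl)cc2Cl)CC1` gives 64 nM in an assay on HEK293 cells for displacement of a labelled ligand from Melanocortin receptor 4 (Homo sapiens) (a lower number here means a stronger inhibitor, a higher number a weaker inhibitor), the lowest of the two numbers measured; compound 1 `CCCCC(N)c1cc(C(F)(F)F)ccc1N1CCN(C(=O)CCc2ccc(Cl)cc2Cl)CC1` gives 190 nM in this assay, and the only measured step is a 3.0-fold lower number from compound 1 to compound 2 (0.47 log units; beyond the scatter). Compound 3 `CCC(C)[C@H](NC(=O)OC)c1cc(C(F)(F)F)ccc1N1CCN(C(=O)CCc2ccc(Cl)cc2Cl)CC1` differs from compound 2 by methoxycarbonyl in place of (pyrrolidin-2-yl)methyl on an amine nitrogen. That earlier step touches the same amine position, and it was modest, so the change here is expected to move the number by a similar modest amount, most likely toward a higher value, as a 4.7-fold higher number from compound 2 to compound 3 (0.67 log units; beyond the scatter). Compound 3 is therefore estimated at 300 nM, within a range from 80 nM to 1200 nM.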

Compound 3, inhibition constant: 2400 nM
Estimate against measurement, compound 3: 8.0-fold (0.90 log units) below; the measured number lies above the stated range.
By their numbers in this assay, from the lowest: compound 2; then compound 1; then compound 3.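

At this amine nitrogen the choice of group matters far more than the earlier step showed: in this assay, methoxycarbonyl in place of (pyrrolidin-2-yl)methyl gives a 38-fold higher number from compound 2 to compound 3 (1.57 log units; beyond the scatter) in the large range. Compound 3 also sits well behind the simple 1-aminopentyl compound, with a 13-fold higher number from compound 1 to compound 3 (1.10 log units; beyond the scatter) as a second large step, so the change does more than undo the earlier gain. Nothing available explains this shift. The compounds shown leave open whether the ring or the carbonyl governs the result, and whether an acetyl or a 2-aminoethyl group on this nitrogen would fall nearer compound 2 or compound 3.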